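A Shorter Chain on a Shared Core

The source may hold more compounds than are shown below. What is called first, only, known or untested is meant among the compounds shown, and "the series" means these compounds.

Compound 1 `Nc1ncnc2c1nc(NCCCCCCCCNC(=O)CI)n2[C@@H]1O[C@H](COP(=O)(O)OP(=O)(O)OP(=O)(O)O)[C@@H](O)[C@H]1O` carries a long saturated chain that ends in a ((iodomethyl)carbonyl)amino group. In an assay on isolated protein for inhibition of hexokinase-3 (Rattus norvegicus), with a stated time of 6 h, tested at 10 mM (on this read-out lower numbers stand for less inhibition and higher numbers for more inhibition at the one concentration tested (going by the name of the read-out)), compound 1 gives 0%. Compound 2 `O=C(CI)NCCCCCC(=O)NCCCCNc1ncnc2c1ncn2[C@@H]1O[C@H](COP(=O)(O)OP(=O)(O)OP(=O)(O)O)[C@@H](O)[C@H]1O`, built on the same core with a different chain, stands level with compound 1 on the digits shown: in this assay compound 2 gives 0%, and the two values fall within the scatter of each other, so no order between them can be read. Compound 3 `Nc1ncnc2c1nc(NCCCCCCNC(=O)CI)n2[C@@H]1O[C@H](COP(=O)(O)OP(=O)(O)OP(=O)(O)O)[C@@H](O)[C@H]1O` has not yet been tested. It differs from compound 1 in one place: ((iodomethyl)carbonyl)amino in place of 2-(((iodomethyl)carbonyl)amino)ethyl on a saturated chain carbon, six bonds along the chain from a nitrogen on an aromatic ring. No step between measured compounds has been shown, so the size of such a change cannot be gauged from the data. Given that compound 1 gives 0% and compound 2 gives 0%, both at the bottom of the read-out, the expectation for compound 3 is that the step of no change at the digits printed from compound 1 to compound 3 (within the scatter) is none beyond the scatter. Compound 3 is therefore expected to give 0%, within a range from -5% to 10%.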

Compound 3, a percentage reported as inhibition, at one concentration (the size of the read-out at that concentration, not a potency): 0%
For compound 3 middle estimate and measured number coincide at the digits printed, and the stated range covers the measured number.
By their numbers in this assay, from the lowest: compounds 1, 2 and 3 (each within the scatter of the next).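

In this assay, placing ((iodomethyl)carbonyl)amino where 2-(((iodomethyl)carbonyl)amino)ethyl stood, on a saturated chain carbon, six bonds along the chain from a nitrogen on an aromatic ring, gives no change at the digits printed from compound 1 to compound 3 (within the scatter). Among the compounds shown here, this is the first direct one-place comparison, and it shows that shortening the chain at this position does not lift the reading, as compound 3 gives 0%. Nothing available explains this outcome.

For the compounds shown here, with both compounds of this step at the bottom of the read-out, the step shows only that this change did not bring out inhibition at the one concentration tested, and it cannot show how chain length would matter in a compound with measurable inhibition. On these data alone, it remains open whether a chain longer than that of compound 1, or an amine or a carboxylic acid in place of the ((iodomethyl)carbonyl)amino group at the chain end, would give a reading above that bottom.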